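The source may report more compounds than this note shows. Statements on the series, on what has been measured and on what is new or still open speak of the compounds shown alone.

Measured compounds:
compound 1 `Cc1ccc(-c2nc(CNc3ccc(C(=O)NO)cc3)n(-c3ccccc3)n2)cc1`, 224 nM
compound 2 `COc1ccc(-n2nc(-c3ccccc3)nc2CNc2ccc(C(=O)NO)cc2)cc1`, 127 nM
compound 3 `O=C(NO)c1ccc(NCc2nc(-c3ccccc3)nn2-c2ccc(Br)cc2)cc1`, 1730 nM

In an assay on Sf9 cells for inhibition of protein deacetylase HDAC6 (Homo sapiens), read by fluorescence, with a stated time of 40 min (a lower number here means a stronger inhibitor, a higher number a weaker inhibitor), compound 1 gives the second highest of the three numbers; compound 2 lies within the scatter of it, compound 3 beyond it. Within the data shown here, the one single-point step known, a 14-fold higher number from compound 2 to compound 3 (1.13 log units; beyond the scatter), concerns the group on the phenyl carried by the ring nitrogen, not the carbon of the shared core changed here. Compound 4 `Cc1ccc(-c2nc(CNc3ccc(C(=O)NO)cc3)n(-c3ccccc3)n2)s1` differs from compound 1 by 5-methylthiophen-2-yl in place of 4-methylphenyl on an aromatic carbon. Among the measured compounds shown here, no measured step bears on this position, so the expectation rests on compound 1 alone: an aromatic ring replaced by another aromatic ring of similar size, expected to give a step of a 1.1-fold higher number from compound 1 to compound 4 (0.05 log units; within the scatter) that stays within the scatter. Compound 4 is therefore estimated at 250 nM, range 100 nM to 650 nM.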

Compound 4, half-maximal inhibitory concentration: 30.6 nM
For compound 4 the middle estimate is 8.2-fold (0.91 log units) above the measured one; measured number outside the range, below it.
By their numbers in this assay, from the lowest: compound 4; then compounds 2 and 1 (each within the scatter of the next); then compound 3.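

With a 7.3-fold lower number from compound 1 to compound 4 (0.86 log units; beyond the scatter) in this assay, 5-methylthiophen-2-yl in place of 4-methylphenyl shows that the aromatic carbon between two ring nitrogen atoms responds to the ring it carries. Exchanging one aromatic ring for another is therefore not a neutral change at this carbon, a point the earlier step on the other phenyl could not show. Nothing at hand accounts for this step. Open, on these data alone, is whether the ring or its methyl matters, which unsubstituted thiophen-2-yl or furan-2-yl at this carbon would address. Also open, as far as these compounds go, is whether 5-methylthiophen-2-yl combines with a methoxy on the phenyl carried by the ring nitrogen.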